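Removing the ethoxy group from compound 2

This account rests on a few compounds, and the source may have more. Where it says the series, first, only, none or still open, it means among the compounds named here.

In a functional assay on DLD-1 cells (Homo sapiens) for cytotoxicity, read by MTT assay (on this read-out higher numbers stand for weaker inhibition and lower numbers for stronger inhibition), compound 1 `COc1cc(/C=C/C(=O)C(=Cc2ccc(OC)c(OC)c2)C(=O)/C=C/c2ccc(O)c(OC)c2)ccc1O` gives 3070 nM, and compound 2 `CCOc1cc(C=C(C(=O)/C=C/c2ccc(O)c(OC)c2)C(=O)/C=C/c2ccc(O)c(OC)c2)ccc1O` gives 4260 nM. For the measured compounds named here, these two numbers lie within the usual scatter of repeated measurements, so compound 2 cannot be told apart from compound 1, the only other compound measured so far.

The next compound is compound 3 `COc1cc(/C=C/C(=O)C(=Cc2ccc(O)cc2)C(=O)/C=C/c2ccc(O)c(OC)c2)ccc1O`. The change is hydrogen in place of ethoxy on an aromatic carbon, which turns 3-ethoxy-4-hydroxyphenyl into 4-hydroxyphenyl.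

Going by the values given here, only one measured step bears on this. The step of a 1.4-fold higher number from compound 1 to compound 2 (0.14 log units; within the scatter) altered the same aromatic group and stayed within the scatter. Among the compounds with values here, no measured pair shows what removing the ethoxy group outright does, so this single small step is weak guidance, and no direction can be argued from it.

In this assay no change beyond the scatter is therefore expected, and the estimated step is a 1.1-fold lower number from compound 2 to compound 3 (0.05 log units; within the scatter). For compound 3 the expected value is 3800 nM, with an estimated range of 1500 nM to 9500 nM.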

Compound 3, half-maximal inhibitory concentration: 4080 nM
The estimate for compound 3 lay 1.1-fold (0.03 log units) below the measured number; measured number inside the range.
By their numbers in this assay, from the lowest: compounds 1, 3 and 2 (each within the scatter of the next).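

In this assay the ethoxy group can be removed outright, with hydrogen taking its place on the aromatic carbon ortho to a hydroxy group, and the result is a 1.0-fold lower number from compound 2 to compound 3 (0.02 log units; within the scatter) so losing these 3 heavy atoms produces no change that can be told from the scatter. Compound 1 carries 3,4-dimethoxyphenyl at this spot, and replacing it with the plainer 4-hydroxyphenyl gives a 1.3-fold higher number from compound 1 to compound 3 (0.12 log units; within the scatter) which means that a ring with nothing on this position now sits alongside the two rings that carry a group there, and none of the three can be separated. Nothing measured alongside these numbers explains why the three compounds read so much alike.

Going by these compounds, it remains open whether this position accepts every group equally: an amine, a carboxylic acid or a longer chain such as butoxy could still move the number in this assay beyond the scatter. The role of the hydroxy group on the same ring is also unresolved, as these three compounds cannot show what would happen with hydrogen in its place.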